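Cytotoxicity of two salicylanilides and an ester analogue

The source may report more compounds than this note shows. Statements on the series, on what has been measured and on what is new or still open speak of the compounds shown alone.

Measured compounds:
Compound 1, `O=C(Nc1cc(C(F)(F)F)cc(C(F)(F)F)c1)c1cc(F)ccc1O`, 2500 nM
Compound 2, `O=C(Nc1cccc(Br)c1)c1cc(Cl)ccc1O`, 5700 nM

Both compounds were tested in an ADME assay on cells (Macrophage, Mus musculus) for cytotoxicity, read by resazurin assay, with a stated time of 3 days; on this read-out higher numbers stand for weaker inhibition and lower numbers for stronger inhibition. Of the two numbers, compound 2 gives the higher one with 5700 nM, and compound 1 the lower one with 2500 nM; the gap between them is wider than the usual scatter, so compound 2 is the weaker inhibitor of cell viability of the pair.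

The next compound, compound 3, `CCOC(=O)c1cccc(NC(=O)c2cc(Cl)ccc2O)c1`, is compound 2 with one change: ethoxycarbonyl in place of bromo on an aromatic carbon. Among the measured compounds shown here, there is no measured pair showing the effect of this particular exchange, so any expectation rests on the two numbers above. The starting point for compound 2 is 5700 nM in this assay. The exchange is expected to move the number only modestly, if at all, and more likely upward than downward, with a step from a 1.4-fold higher number from compound 2 to compound 3 (0.15 log units; within the scatter) that may stay within the scatter. Compound 3 is therefore expected to give about 8000 nM, within a range from 3000 nM to 25000 nM.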

Compound 3, half-maximal inhibitory concentration: 17000 nM
Estimate against measurement, compound 3: 2.1-fold (0.33 log units) below; the range from low to high includes it.
By their numbers in this assay, from the lowest: compound 1; then compound 2; then compound 3.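

In this assay, among the compounds shown here, compounds 2 and 3 form the first pair here that differs in only one place, so the effect of a single exchange can be read on its own. Replacing bromo with ethoxycarbonyl gives a 3.0-fold higher number from compound 2 to compound 3 (0.47 log units; beyond the scatter), a step beyond the usual scatter, which shows that this position, on a six-membered aromatic ring of carbon only and meta to a large group, is not indifferent to what it carries: the larger group, with its five heavy atoms and two hydrogen-bond acceptors, goes with weaker inhibition in these mouse macrophages. No measurement shown here explains why the number rises.

This single pair cannot separate the contributions of group size, the hydrogen-bond acceptors and any other difference between bromo and ethoxycarbonyl, nor show whether the same exchange would have a similar effect on another core. A carboxylic acid, a nitrile or an amine on the same aromatic carbon would show whether the higher number is particular to ethoxycarbonyl or extends to other replacements for bromo.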